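Dropping the Methyl on the Shared Core

The source may hold more compounds than are shown below. What is called first, only, known or untested is meant among the compounds shown, and "the series" means these compounds.

Of the compounds shown here, three built on one shared core have been tested in an ADME assay on HeLa cells (Homo sapiens) for cytotoxicity; on this read-out lower numbers stand for higher toxicity in this test and higher numbers for lower toxicity in this test. Compound 1 `N=C(NO)N/N=C/c1ccc(Cl)cc1` gives > 100000 nM in this assay, which is a limit of the assay rather than a number. Compound 2 `CN(C)c1ccc(/C=N/NC(=N)NO)cc1` gives > 100000 nM, likewise a limit. Compound 3 `Cc1ccccc1/C=N/NC(=N)NO` gives > 100000 nM, again a limit. Since the values of compound 1 and compound 2 are both limits, the step that the two limits leave unreadable from compound 1 to compound 2 cannot be read. All three values sit at the limit of > 100000 nM in this assay, at which 3 of the 3 values shown sit.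

Compound 4 `N=C(NO)N/N=C/c1ccccc1` differs from compound 3 by hydrogen in place of methyl on an aromatic carbon. For the measured compounds named here, the only measured step, from compound 1 to compound 2, has no readable size and does not touch the methyl group, so it gives no guide to the direction of this change. Going by the values given here, because every value so far sits at the limit of > 100000 nM in this assay, at which 3 of the 3 values shown sit, the expectation is that compound 4 will also show no measurable toxicity within the tested range. The expected step is a number no higher from compound 3 to compound 4 (the limit leaves the size open), within the scatter. Compound 4 is therefore estimated at 100000 nM, with a range from 30000 nM to 300000 nM.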

Compound 4, half-maximal cytotoxic concentration: > 100000 nM
Compound 4 ended at the assay's limit; the forecaster's own chance of this, stated with the estimate: 70%; the middle value lies on the limit itself.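

Compound 4, like compound 1, compound 2 and compound 3, sits at a limit in this assay, so none of the steps from those three to compound 4 can be read. The compounds shown leave open whether any of them differ in toxicity, and at what concentration any toxicity would appear: the limit of > 100000 nM in this assay, at which 4 of the 4 values shown sit.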